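The source may hold more compounds than are shown below. What is called first, only, known or untested is meant among the compounds shown, and "the series" means these compounds.

Working notes on the series.

Of the compounds shown here, two carry numbers so far. Compound 1 `Cc1c(OCCCCOc2cccc(C(=O)O)c2)ccc(C(=O)CC(C)C)c1C` in an assay on HEK293 cells for positive allosteric modulation of metabotropic glutamate receptor 2 (Rattus norvegicus), read by thallium flux, with a stated time of 2.5 min (on this read-out lower numbers stand for smaller maximal responses and higher numbers for larger maximal responses), gives 12.1%; compound 2 `Cc1ccc(C(=O)O)cc1OCCCCOc1ccc(C(=O)CC2CCCC2)c(O)c1C` in this assay gives 67.5%. Compound 1 thus stands lowest of the two numbers, with compound 2 the nearest neighbour at a value a good deal higher, a gap that lies beyond the scatter. The two structures differ in more than one place, so the gap between them cannot be tied to any single change, and nothing more is read from it here.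

The step now followed leads from compound 1 to compound 3 `Cc1c(OCCCCOc2ccccc2C(=O)O)ccc(C(=O)CC(C)C)c1C`. The change is 2-carboxyphenyl in place of 3-carboxyphenyl on an oxygen on a saturated carbon. The rest of the molecule is kept as it stands in compound 1. For the measured compounds named here, no pair among the measured compounds differs in one place, so no step of the same kind is at hand to set a size or direction.

Expectation: for compound 3 in this assay a value near 18% is estimated, within about 5% to 50%. This is expected to mean a step from compound 1 to compound 3 of a number 5.9 percentage points higher from compound 1 to compound 3 (within the scatter), most likely not beyond the scatter, since compound 1 already sits low at 12.1% and the moved acid gives no reason in the present numbers to expect a large rise.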

Compound 3, largest response reached (reported as percent of maximum), in percent of the reference or control that the assay uses: 76.2%
The estimate for compound 3 lay 58.2 percentage points below the measured number, and the stated range ends below it.
By their numbers in this assay, from the lowest: compound 1; then compounds 2 and 3 (each within the scatter of the next).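

In this assay, for the compounds shown here, 2-carboxyphenyl in place of 3-carboxyphenyl on an oxygen on a saturated carbon gives a number 64.1 percentage points higher from compound 1 to compound 3 (beyond the scatter) and is the first change that can be tied to one place. The group that leaves and the group that enters have the same atoms, the same ring and the same counts of hydrogen-bond donors and acceptors, so this step shows that, on the core of compound 1, the maximal response depends strongly on how these same atoms are joined, not on which atoms are present. No measurement at hand bears on the reason for this difference.

Going by these compounds, it remains open whether the same change would give a step of similar size on the core of compound 2, which differs from compound 1 and compound 3 in more than one place. On these data alone, it also remains open whether the carboxylic acid is itself required in the 2-carboxyphenyl group, as a tetrazole or a primary amide in its place would test, and whether the response holds with a longer chain between the two oxygens.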